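From compound 3 to compound 4: one added methoxy

This account rests on a few compounds, and the source may have more. Where it says the series, first, only, none or still open, it means among the compounds named here.

In an ADME assay on K562 cells (Homo sapiens) for cytotoxicity, with a stated time of 72 h (on this read-out higher numbers stand for weaker inhibition and lower numbers for stronger inhibition), compound 3 (`COc1cccc(CNc2ncnc3c2ncn3C2CCCO2)c1`) gives > 100000 nM and this is a limit of the assay, not a number. Compound 2 (`COc1ccccc1CNc1ncnc2c1ncn2C1CCCO1`) gives > 100000 nM and this too is a limit. Compound 3 thus stands with compound 2 at the limit of > 100000 nM in this assay, at which 2 of the 3 values shown sit, and has no number from which a step can be counted.

Compound 4 (`COc1ccc(OC)c(CNc2ncnc3c2ncn3C2CCCO2)c1`) follows from compound 3 by methoxy in place of hydrogen on an aromatic carbon and nothing else changes. Going by the values given here, the only measured step is a step that the two limits leave unreadable from compound 2 to compound 3 and it sets no scale for this change. Among the compounds with values here, the one number available comes from compound 1 (`COc1ccc(OC)c(CNc2ncnc3c2ncn3C2CCCCO2)c1`), which gives 16500 nM in this assay and shares its methoxy groups with compound 4 while differing elsewhere. On the strength of that value for compound 1, a move toward stronger inhibition is expected, of uncertain size, and a further limit reading remains quite possible. The expected change is an at least 2.5-fold lower number from compound 3 to compound 4 (0.39 log units; beyond the scatter) as an estimate, in the direction of lower numbers. Compound 4 is estimated at 40000 nM in this assay with an expected range from 12000 nM to 100000 nM on this estimate.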

Compound 4, half-maximal inhibitory concentration: > 50000 nM
Compound 4: no number, only a limit; the forecaster's own chance of this, stated with the estimate: 45%; at least 1.2-fold (0.09 log units) between middle value and limit.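

The added methoxy, para to a methoxy group, yields no readable step: the steps into compound 4 from compound 2 and from compound 3 cannot be read, because all three values are limits of the assay: the limit of > 100000 nM in this assay, at which 2 of the 4 values shown sit.

In this assay compound 4 gives > 50000 nM and this is a limit, not a number: the limit of > 50000 nM in this assay, at which 1 of the 4 values shown sits.

Going by these compounds alone, the first readable step is an at least 3.0-fold higher number from compound 1 to compound 4 (0.48 log units; beyond the scatter) with oxolan-2-yl in place of oxan-2-yl on an aromatic nitrogen as the one change, so with both methoxy groups held in place the group on that nitrogen moves the read-out.

The compounds shown leave open what the second methoxy does on the oxan-2-yl side, where compound 1 stands alone, and whether the oxolan-2-yl side can give a number at all. Also open, going by these compounds, is what an amine or a carboxylic acid in place of the methoxy at this position would give with either group on the nitrogen.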